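Turning two ring stereocentres in a methyl-pyridine ether

The source may hold more compounds than are shown below. What is called first, only, known or untested is meant among the compounds shown, and "the series" means these compounds.

Measured so far:
compound 1 `COc1ccc(OC[C@@H]2C[C@@H]3C[C@@H]3N2)cn1`: 4.7 nM
compound 2 `Fc1ccc(OC[C@@H]2C[C@@H]3C[C@@H]3N2)cn1`: 1.2 nM
compound 3 `Cc1ccc(OC[C@@H]2C[C@H]3C[C@H]3N2)cn1`: 26.2 nM

In an assay on CHO-K1 cells for displacement of a labelled ligand from Neuronal acetylcholine receptor; alpha4/beta2 (Homo sapiens), read by scintillation counting (a lower number here means a stronger inhibitor, a higher number a weaker inhibitor), compound 3 gives the highest of the three numbers; compound 1 sits closer to it, compound 2 further away. Compound 4 `Cc1ccc(OC[C@@H]2C[C@@H]3C[C@@H]3N2)cn1` differs from compound 3 only in configuration: the two compounds have the same atoms and bonds and differ only in configuration as drawn: 2 of 3 stereo elements differ; a stereocentre at a saturated ring carbon is drawn R in compound 3 and S in compound 4; a stereocentre at a saturated ring carbon is drawn R in compound 3 and S in compound 4. Compound 4 thus carries the same configuration as compounds 1 and 2. For the measured compounds named here, the only measured step, a 3.9-fold lower number from compound 1 to compound 2 (0.59 log units; beyond the scatter), swaps a group and says nothing about configuration. Going by the values given here, no measured pair isolates this stereo change, so the expectation rests on compounds 1 and 2 with their low values. The expected step is a 6.6-fold lower number from compound 3 to compound 4 (0.82 log units; beyond the scatter), towards a lower number. For compound 4 the estimate is 4 nM, within 1 nM to 16 nM.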

Compound 4, inhibition constant: 1.38 nM
Compound 4: middle estimate off by 2.9-fold (0.46 log units), on the high side; low and high end bracket the measured number.
By their numbers in this assay, from the lowest: compounds 2 and 4 (each within the scatter of the next); then compound 1; then compound 3.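

Changing configuration alone gives a 19-fold lower number from compound 3 to compound 4 (1.28 log units; beyond the scatter) in this assay, and this step can be assigned to stereochemistry because nothing else separates the pair: the fact that compounds 3 and 4 differ only in the configuration as drawn. With this configuration held, methyl and fluoro on the aromatic carbon cannot be told apart, a 1.2-fold higher number from compound 2 to compound 4 (0.06 log units; within the scatter), whereas replacing methoxy with methyl gives a 3.4-fold lower number from compound 1 to compound 4 (0.53 log units; beyond the scatter).

Going by these compounds, whether one of the two ring stereocentres accounts for most of the step remains open, as does whether it holds with fluoro or methoxy. How a nitrile or an amine on that aromatic carbon would read is also unknown.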